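The compounds below may be only part of what the source reports. "The series", "measured", "known", "first", "only" and "open" are said of these compounds alone.

Measured in a functional assay for antagonist activity, with Cavia porcellus as the target; a lower number here means a stronger inhibitor, a higher number a weaker inhibitor:
- Compound 1 `CCN(C)CC#CCCC1SCCCS1`: > 10000000 nM (a limit)
- Compound 2 `CN(C)CC#CCCC1SCCCS1`: > 10000000 nM (a limit)

Compound 1 has no number in this assay, only the limit > 10000000 nM. The same holds for the whole set so far, which stands at the limit of > 10000000 nM in this assay, at which 2 of the 2 values shown sit. Among the compounds with values here, the single measured step, a step that the two limits leave unreadable from compound 1 to compound 2, therefore gives no size to build on.

Compound 3 `CN(CC#CCCC1SCCCS1)CCCc1ccccc1` has not yet been measured. The change is benzyl in place of hydrogen on a saturated chain carbon, two bonds along the chain from an amine nitrogen, which brings in one six-membered aromatic ring of carbon only. Within the data shown here, no measured step covers this change, so any expected size is a loose judgement. Compound 1 gives a reading only as a limit, > 10000000 nM, so the one readable outcome would be a move toward a stronger inhibitor. Another limit remains quite possible.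

The expected change, if a number is reported at all, is an at least 10-fold lower number from compound 1 to compound 3 (1.00 log units; beyond the scatter). For compound 3 the estimated value is 1000000 nM, with an expected range from 30000 nM to 10000000 nM.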

Compound 3, antagonist equilibrium constant: 2980 nM
Compound 3: middle estimate off by 340-fold (2.53 log units), on the high side, and the stated range ends above it.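

In this assay, compound 3 is the only one of the compounds shown that gives a number and not a limit: the limit of > 10000000 nM in this assay, at which 2 of the 3 values shown sit.

Within the data shown here, the earlier compounds showed only that the one step among them cannot be read, whereas benzyl in place of hydrogen on a saturated chain carbon, two bonds along the chain from an amine nitrogen, gives a step that can be read, an at least 3300-fold lower number from compound 1 to compound 3 (3.52 log units; beyond the scatter). With compound 1 held at a limit, this size is a floor on the effect of the change, and it shows that this position accepts the added group and that the change moves the compound into the measurable range of this read-out.

The compounds shown leave open whether the step depends on the aromatic ring itself, or whether a cyclohexyl ring on the same chain would give a similar reading in this assay. They also leave open how a shorter or longer chain carrying the phenyl ring would read, and what a chlorine atom on that ring would do.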